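This account rests on a few compounds, and the source may have more. Where it says the series, first, only, none or still open, it means among the compounds named here.

Among the measured compounds shown here, the shared core is the one of compound 1 `CS(=O)(=O)c1ccc(C(=O)Nc2ccc(Cl)c(-c3nnc4c(Cl)cccn34)c2)c(Cl)c1`, which in a functional assay on T47D cells (Homo sapiens) for antiproliferative activity, read by MTT assay, with a stated time of 72 h (on this read-out lower numbers stand for stronger inhibition and higher numbers for weaker inhibition), gives a limit of the assay rather than a number, at > 100000 nM. For the measured compounds named here, compound 2 `O=C(Nc1ccc(Cl)c(-c2nnc3c(Cl)cccn23)c1)c1ccccc1Cl` is the only member of the series with a numeric reading, and in this assay compound 2 gives 83800 nM. The change an at least 1.1-fold lower number from compound 1 to compound 2 (0.07 log units; that floor lies within the scatter) is therefore only a floor and tells nothing beyond the scatter. Compound 3 `O=C(Nc1ccc(Cl)c(-c2nnc3c(Cl)cccn23)c1)c1ccon1` again sits at a limit of the assay, and in this assay compound 3 gives > 100000 nM. Where compound 3 stands is thus only a bound, and the step of an at least 1.1-fold higher number from compound 2 to compound 3 (0.07 log units; that floor lies within the scatter) is likewise only a floor; the limit of > 100000 nM in this assay, at which 2 of the 3 values shown sit, holds two of the three readings, so the whole series is at the weak end of the window.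

Compound 4 `O=C(Nc1ccc(Cl)c(-c2nnc3c(Cl)cccn23)c1)c1ccc(F)cc1Cl` brings the change (2-chloro-4-fluorophenyl in place of 1,2-oxazol-3-yl on a carbonyl carbon). The new acyl group resembles that of compound 2, which gave 83800 nM, so the nearest guide is a return to that level rather than a large gain. The step of an at least 1.4-fold lower number from compound 3 to compound 4 (0.15 log units; that floor lies within the scatter) is expected to run toward a lower number but not far beyond the scatter. For compound 4 the estimate in this assay is 70000 nM, in the range 20000 nM to 150000 nM, with a fair chance that only a limit is reported.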

Compound 4, half-maximal inhibitory concentration: > 100000 nM
Compound 4: a limit, no number; the forecaster's own chance of this, stated with the estimate: 40%; middle value at least 1.4-fold (0.15 log units) away from the limit.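

Among the compounds shown here, the one readable step is an at least 1.1-fold higher number from compound 2 to compound 4 (0.07 log units; that floor lies within the scatter), so fluoro in place of hydrogen on an aromatic carbon gives no sign of a gain in this assay. The steps to compound 4 from compound 3 and from compound 1 join two limits and cannot be read. Compound 2 remains the only compound with a numeric reading, and with compound 4 the limit now holds most of the series: the limit of > 100000 nM in this assay, at which 3 of the 4 values shown sit.

Still open, as far as these compounds go, is whether any group on this carbonyl carbon can bring a reading well inside the window of the assay, which an aliphatic amine or a carboxylic acid on the aromatic ring, or a longer alkyl chain in place of that ring, would help to test. Also open, from the compounds shown here alone, is how far compound 1, compound 3 and compound 4 lie from one another, since their limits give no numbers to compare.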